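A Bromine Removed: What It Did, What It May Do

The source may hold more compounds than are shown below. What is called first, only, known or untested is meant among the compounds shown, and "the series" means these compounds.

Of the compounds shown here, three have so far been measured in a functional assay on Caco-2 cells (Homo sapiens) for inhibition, read by MTT assay, with a stated time of 48 h; a lower number here means a stronger inhibitor, a higher number a weaker inhibitor. Compound 1 `COc1cc(/C=N/Nc2nc(-c3cccc(Br)c3)cs2)cc(Br)c1OC` gives 43400 nM. In this assay compound 2 `Fc1ccc(/C=N/Nc2nc(-c3ccc(Br)cc3)cs2)cc1F` gives 43900 nM, a number within the usual scatter of that of compound 1, so the two cannot be told apart. Compound 3 `COc1cc(/C=N/Nc2nc(-c3cccc(Br)c3)cs2)c(Br)c(Br)c1OC` reaches only a limit of this assay, > 100000 nM.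

Compound 3 and compound 1 differ in one place: hydrogen in place of bromo on an aromatic carbon. Going by these compounds, that change produced an at least 2.3-fold lower number from compound 3 to compound 1 (0.36 log units; beyond the scatter), and its full size stays open because the starting point is a limit (the limit of > 100000 nM in this assay, at which 1 of the 3 values shown sits).

Compound 4 `Fc1ccc(/C=N/Nc2nc(-c3ccccc3)cs2)cc1F` has not yet been measured. It differs from compound 2 by the same kind of change, (hydrogen in place of bromo on an aromatic carbon), but the surroundings are not the same: in compound 3 the carbon is ortho to a bromo group, ortho to a large group, meta to a methoxy group and para to a methoxy group, whereas in compound 2 it is para to a large group. How the cores of compound 2 and compound 3 differ is not broken down here.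

The expected step is a 1.3-fold higher number from compound 2 to compound 4 (0.10 log units; within the scatter), kept small because compound 2 gives 43900 nM. The one earlier removal of a bromo, at a differently surrounded place, is bounded by a limit of > 100000 nM in this assay, at which 1 of the 3 values shown sits, and so gives only a loose guide. Compound 4 is therefore expected to land at about 55000 nM, between 20000 nM and 150000 nM.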

Compound 4, half-maximal inhibitory concentration: 20900 nM
For compound 4 the middle estimate is 2.6-fold (0.42 log units) above the measured one; the range from low to high includes it.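

In this assay, replacing the bromo with hydrogen, which turns the 4-bromophenyl of compound 2 into a plain phenyl, gives a 2.1-fold lower number from compound 2 to compound 4 (0.32 log units; beyond the scatter). This is the second time that hydrogen in place of bromo on an aromatic carbon has lowered the number, and it did so on two different cores and at two differently surrounded carbons, so the direction of the change carried over in the one case that can be checked: the same change on two cores in this assay, an at least 2.3-fold lower number (0.36 log units; beyond the scatter) from compound 3 to compound 1 and a 2.1-fold lower number (0.32 log units; beyond the scatter) from compound 2 to compound 4; the limit leaves it open whether they differ The value of compound 3 is a limit of the assay and not a number, so the true size of the earlier step remains unknown, and two pairs of compounds give no rule for any other core in this series: the limit of > 100000 nM in this assay, at which 1 of the 4 values shown sits.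

The compounds shown leave open whether the lower number comes with hydrogen in particular, or whether a chloro, a methyl group or an amine on that same carbon would give a number like that of compound 4 or one like that of compound 2. They also leave open what removing a bromo from the other ring of compound 1 would do in this assay.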